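Cytotoxicity on Bovine Kidney Cells Across Three Close Analogues

This account rests on a few compounds, and the source may have more. Where it says the series, first, only, none or still open, it means among the compounds named here.

Measured so far:
compound 1 `Cc1ccc(Cn2ccc3nc(-c4ccccc4)nc-3c2)cc1` in an ADME assay on MDBK cells (Bos taurus) for cytotoxicity; on this read-out higher numbers stand for lower toxicity in this test and lower numbers for higher toxicity in this test: > 100000 nM
compound 2 `FC(F)(F)c1ccc(Cn2ccc3nc(-c4ccccc4)nc-3c2)cc1` in this assay: 84000 nM

Two compounds carry numbers. For compound 1 the result is a limit of the assay, > 100000 nM. Compound 2 gives 84000 nM. Among the compounds with values here, the one measured step between them, an at least 1.1-fold lower number from compound 1 to compound 2 (0.07 log units; that floor lies within the scatter), does not leave the scatter, so the trifluoromethyl for methyl exchange shows no real movement here. Compound 1 therefore stands at the ceiling of the test, which is the situation recorded as the limit of > 100000 nM in this assay, at which 1 of the 2 values shown sits.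

Compound 3 `c1ccc(CCCn2ccc3nc(-c4ccccc4)nc-3c2)cc1` has not yet been measured. It differs from compound 1 in one place: phenethyl in place of 4-methylphenyl on a saturated chain carbon bound to an aromatic nitrogen. Within the data shown here, no measured step touches a change of this kind; the only step known concerns a substituent on the aromatic ring and stayed within the scatter. With nothing pointing either way, no movement beyond the scatter is expected. Compound 3 is thus expected to give about 100000 nM in this assay, within the range 40000 nM to 250000 nM. That estimate corresponds to an expected step of a number no higher from compound 1 to compound 3 (the limit leaves the size open), itself within the scatter.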

Compound 3, half-maximal cytotoxic concentration: > 100000 nM
Compound 3 was reported as a limit; the forecaster's own chance of this, stated with the estimate: 50%; the middle value lies on the limit itself.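

Compound 1 and compound 3 both end at a limit of this assay, so no step between them can be read: the limit of > 100000 nM in this assay, at which 2 of the 3 values shown sit.

The compounds shown leave open whether phenethyl in place of 4-methylphenyl changes this read-out at all, and how far beyond the limit compound 1 and compound 3 lie.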